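A few compounds are considered here, and "the series" means these few. Any claim that something is new, unique, unknown or untested is made for them only; others in the source may bear on it.

Values so far in a functional assay on MCF7 cells (Homo sapiens) for antiproliferative activity, read by MTT assay, with a stated time of 72 h; on this read-out higher numbers stand for weaker inhibition and lower numbers for stronger inhibition:
- compound 1 `CCn1c(C(=O)NCC(=O)O)ccc1C(CC)(CC)c1ccc(C#CC(O)(CC)CC)c(C)c1`: 5140 nM
- compound 2 `CCn1cc(C(CC)(CC)c2ccc(C#CC(O)(CC)CC)c(C)c2)cc1C(=O)NCCN(C)C`: 13400 nM

Of these two, compound 2 at 13400 nM has the higher number and so the weaker inhibition, and its gap to compound 1 lies beyond the scatter. The next compound to be read is compound 3 `CCCCC(=O)c1cc(C(CC)(CC)c2ccc(C#CC(O)(CC)CC)c(C)c2)cn1CC`, which departs from compound 2 in one place: butyl in place of (2-(dimethylamino)ethyl)amino on a carbonyl carbon.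

Going by the values given here, no measured pair differs in one place only, so this change has no direct calibration. Among the compounds with values here, the only guide is the span of the two values, where compound 1 at 5140 nM shows that a lower number occurs. In this assay a modest step towards a lower number is expected, one that may barely clear the scatter, and the range is kept wide. The estimated step is a 2.2-fold lower number from compound 2 to compound 3 (0.35 log units; beyond the scatter). For compound 3 the expected value is 6000 nM, with an estimated range of 1800 nM to 18000 nM.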

Compound 3, half-maximal inhibitory concentration: > 50000 nM
Compound 3: a limit, no number (the forecaster's own chance of this, stated with the estimate: 10%); at least 8.3-fold (0.92 log units) between middle value and limit.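

In this assay compound 3 gives > 50000 nM, which is a limit of the assay and not a number. Butyl in place of (2-(dimethylamino)ethyl)amino on a carbonyl carbon supplies the first one-place step in the series, and it runs towards weaker inhibition, with an at least 3.7-fold higher number from compound 2 to compound 3 (0.57 log units; beyond the scatter), so this position is sensitive to the group it carries and the change removes both nitrogens counted on the leaving group. That step gives only a minimum size, and the full size of the change stays unread: the limit of > 50000 nM in this assay, at which 1 of the 3 values shown sits.

Going by these compounds alone, the single pair does not separate the contribution of the amide hydrogen, the terminal dimethylamino group or the chain length, since all of them change together, and compound 1 differs from both other compounds in more than one place and so gives no reading on this question. Still open, from the compounds shown here alone, is how a primary amide, a shorter alkyl chain, a morpholine or a carboxylic acid on the same carbonyl carbon would read against compound 2.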